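This account rests on a few compounds, and the source may have more. Where it says the series, first, only, none or still open, it means among the compounds named here.

In a functional assay on U-251 cells (Homo sapiens) for antiproliferative activity, read by MTT assay, with a stated time of 48 h (on this read-out lower numbers stand for stronger inhibition and higher numbers for weaker inhibition), three compounds on a shared core have been measured: compound 1 `COc1cc(-c2cccc3nc(-c4ccccc4)oc23)cc(OC)c1OC` gives 3500 nM, compound 2 `COc1cc(-c2cccc3nc(-c4cccc(F)c4)oc23)cc(OC)c1OC` gives 2900 nM, and compound 3 `COc1cc(-c2cccc3nc(-c4cccc(Br)c4)oc23)cc(OC)c1OC` gives 6800 nM. The standing of compound 3 rests on two steps: a 2.3-fold higher number from compound 2 to compound 3 (0.37 log units; beyond the scatter), and a 1.9-fold higher number from compound 1 to compound 3 (0.29 log units; within the scatter). Compound 4 `COc1cc(-c2cccc3nc(-c4cccc(C)c4)oc23)cc(OC)c1OC` differs from compound 3 by methyl in place of bromo on an aromatic carbon, meta to a large group. Going by the values given here, no measured step makes this exchange, and no methyl compound has yet been measured. The closest evidence is the replacement of hydrogen in compound 1, which gave a 1.2-fold lower number from compound 1 to compound 2 (0.08 log units; within the scatter), alongside the modest exchange of fluoro for bromo already noted. These steps are all small, so only a small change is expected in this assay, leaning towards the numbers of compound 1 and compound 2. The expected step is a 1.7-fold lower number from compound 3 to compound 4 (0.23 log units; within the scatter), which would not be a clear change. For compound 4 the estimated value is 4000 nM, with an expected range of 1800 nM to 8000 nM.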

Compound 4, half-maximal inhibitory concentration: > 25000 nM
Compound 4 gave a limit, no number (the forecaster's own chance of this, stated with the estimate: 3%); middle value at least 6.2-fold (0.79 log units) from the limit.
By their numbers in this assay, from the lowest: compounds 2, 1 and 3 (each within the scatter of the next, the first and the last beyond it). At a limit, above all of these: compound 4.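

In this assay compound 4 stands at a limit and not at a number: the limit of > 25000 nM in this assay, at which 1 of the 4 values shown sits. Exchanges among hydrogen, fluoro and bromo on this aromatic carbon, meta to a large group, had kept the numbers of compounds 1, 2 and 3 within a narrow span, whereas methyl gives the largest steps in the series, against each of the three (an at least 3.6-fold higher number from compound 3 to compound 4 (0.56 log units; beyond the scatter); an at least 8.6-fold higher number from compound 2 to compound 4 (0.93 log units; beyond the scatter); an at least 7.1-fold higher number from compound 1 to compound 4 (0.85 log units; beyond the scatter)). Bromo and methyl each count one heavy atom, so the 3-bromophenyl to 3-methylphenyl change shows that this position can separate two groups of equal heavy-atom count.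

The compounds shown do not say why methyl differs from bromo here, and no cause can be drawn from them. They also leave open whether an ethyl, a methoxy or an amine at this place would follow methyl or stay with the halogens.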